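A few compounds are considered here, and "the series" means these few. Any claim that something is new, unique, unknown or untested is made for them only; others in the source may bear on it.

Measured compounds: compound 1 `Cc1cccc(/C(N)=N/NC(=S)N2CCN(c3ccccn3)CC2)n1`, > 100000 nM; compound 2 `N/C(=N\NC(=S)N1CCOCC1)c1ccccn1`, 4700 nM.

In a functional assay on MCF7 cells (Homo sapiens) for cytotoxicity, read by MTT assay, with a stated time of 72 h (on this read-out lower numbers stand for stronger inhibition and higher numbers for weaker inhibition), compound 1 reaches only a limit of the assay, > 100000 nM, so compound 1 sits at the limit of > 100000 nM in this assay, at which 1 of the 2 values shown sits, the weaker end of the two values shown. In this assay compound 2 gives 4700 nM. Compound 3 `N/C(=N\NC(=S)N1CCN(c2ccccn2)CC1)c1ccc(F)cn1` is not yet measured; it differs from compound 1 by 5-fluoropyridin-2-yl in place of 6-methylpyridin-2-yl on a carbon with a double bond to nitrogen. Among the compounds with values here, no measured pair shows what this change does, so the expected step from compound 1 to compound 3 is an at least 3.3-fold lower number from compound 1 to compound 3 (0.52 log units; beyond the scatter), towards stronger inhibition but very uncertain. Compound 3 is estimated at 30000 nM, between 5000 nM and 200000 nM.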

Compound 3, half-maximal inhibitory concentration: 22000 nM
For compound 3 the middle estimate is 1.4-fold (0.13 log units) above the measured one, within the range that was stated.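

In this assay, 5-fluoropyridin-2-yl in place of 6-methylpyridin-2-yl on a carbon with a double bond to nitrogen gives an at least 4.5-fold lower number from compound 1 to compound 3 (0.65 log units; beyond the scatter), so this position can shift the result towards stronger inhibition. Compound 1 stands at a limit of the assay, so the step gives only a minimum size: the limit of > 100000 nM in this assay, at which 1 of the 3 values shown sits.

The compounds shown leave open whether losing the methyl or gaining the fluorine carries this step. They also leave open whether a chlorine or a methoxy group on this ring would act like the fluorine.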